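Acetylpiperidinyl replaces ethyl on the benzimidazole-type core

The compounds below may be only part of what the source reports. "The series", "measured", "known", "first", "only" and "open" are said of these compounds alone.

Of the compounds shown here, three sharing one core have been measured in an assay on Huh-7 cells for agonist activity at Bile acid receptor (Homo sapiens), read by a luciferase reporter; a higher number here means that more compound is needed for the effect, a lower number that less compound is needed. Compound 1 `CC(C)c1onc(-c2c(Cl)cccc2Cl)c1COc1ccc(-c2nc3ccc(C(=O)O)cc3n2CC2CCCCC2)c(F)c1` gives 7.8 nM, compound 3 `CC(C)c1onc(-c2c(Cl)cccc2Cl)c1COc1ccc(-c2nc3ccc(C(=O)O)cc3n2CC2CCCCC2)c(Cl)c1` gives 7.6 nM, and compound 2 `CCn1c(-c2ccc(OCc3c(-c4c(Cl)cccc4Cl)noc3C(C)C)cc2)nc2ccc(C(=O)O)cc21` gives 2.31 nM. For the measured compounds named here, the one single-point step among them, a 1.0-fold lower number from compound 1 to compound 3 (0.01 log units; within the scatter), shows that exchanging the halogen on the aromatic carbon leaves the number unchanged. Compound 2 stands lowest of the three: its gaps to compound 3 and to compound 1 both lie beyond the scatter.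

Compound 4 `CC(=O)N1CCC(n2c(-c3ccc(OCc4c(-c5c(Cl)cccc5Cl)noc4C(C)C)cc3)nc3ccc(C(=O)O)cc32)CC1` differs from compound 2 in one place: 1-acetylpiperidin-4-yl in place of ethyl on an aromatic nitrogen. Going by the values given here, no measured step touches the group on the aromatic nitrogen, so the one step available, which concerns a halogen elsewhere, does not bear on this change. Compounds 1 and 3 carry a different group at that position but also a different halogen, and only their values, higher than that of compound 2, can be compared. A modest rise in this assay is therefore expected for compound 4, estimated at 8 nM within 2.5 nM to 25 nM, a step of a 3.5-fold higher number from compound 2 to compound 4 (0.54 log units; beyond the scatter).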

Compound 4, half-maximal effective concentration: 1430 nM
Beside the measured number, compound 4's estimate is 180-fold (2.25 log units) below it, outside the stated range (above it).
By their numbers in this assay, from the lowest: compound 2; then compounds 3 and 1 (each within the scatter of the next); then compound 4.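

In this assay, 1-acetylpiperidin-4-yl in place of ethyl on the aromatic nitrogen gives a 620-fold higher number from compound 2 to compound 4 (2.79 log units; beyond the scatter) as a large step. For the compounds shown here, this is the only measured step at this position, and it shows that the number responds strongly to the group on that nitrogen, whereas the earlier single-point step, at a halogen elsewhere, stayed within the scatter. The entering group brings a six-membered non-aromatic ring with 1 hetero atom, a double bond outside aromatic rings and a hydrogen-bond acceptor together, so the step cannot be divided among these features.

Nothing available here bears on the reason for this rise. As far as these compounds go, it remains open whether a piperidine ring with a free amine, a cyclohexyl ring or a propyl chain on that nitrogen would stay close to compound 2 or rise as compound 4 does.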